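The source may report more compounds than this note shows. Statements on the series, on what has been measured and on what is new or still open speak of the compounds shown alone.

Compound 2 `Sc1nc(NCc2ccccc2)c2ccccc2n1` and compound 1 `COc1ccc(CNc2nc([Se]C)nc3ccccc23)cc1` have both been tested in a functional assay on HTB-54 cells (Homo sapiens) for cytotoxicity, read by MTT assay, with a stated time of 72 h; on this read-out higher numbers stand for weaker inhibition of growth and lower numbers for stronger inhibition of growth. In this assay compound 2 gives 15200 nM, the lowest of the two numbers, while compound 1 gives 33000 nM, a number that is higher by more than the usual scatter. The next compound, compound 3 `COc1ccc(CNc2nc(S)nc3ccccc23)cc1`, is compound 2 with one change: methoxy in place of hydrogen on an aromatic carbon. Within the data shown here, no pair of measured compounds differs by exactly this change, so the size of the step cannot be read directly from the data. Compound 1 also carries a methoxy group and in this assay gives 33000 nM, but it differs from compound 3 at a second position as well, so that comparison is not clean. Compound 3 is therefore expected to give 18000 nM in this assay, within a range of 8000 nM to 40000 nM. This estimate means a step of a 1.2-fold higher number from compound 2 to compound 3 (0.07 log units; within the scatter), which is expected to lie within the scatter.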

Compound 3, concentration for 50% growth inhibition: 13500 nM
Compound 3: middle estimate off by 1.3-fold (0.12 log units), on the high side; low and high end bracket the measured number.
By their numbers in this assay, from the lowest: compounds 3 and 2 (each within the scatter of the next); then compound 1.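

In this assay, methoxy in place of hydrogen on an aromatic carbon, para to a large group, gives a 1.1-fold lower number from compound 2 to compound 3 (0.05 log units; within the scatter), so at this position the change does not separate the two compounds. The sulfur atom in place of the group of one carbon and one selenium atom gives a 2.4-fold lower number from compound 1 to compound 3 (0.39 log units; beyond the scatter), and of the two single changes now readable only this one lies beyond the scatter, though it remains a modest step. Nothing at hand offers a reason for the size of either step.

Going by these compounds, whether an amine, a carboxylic acid or a longer chain such as butoxy would behave like methoxy on this aromatic carbon stays open. So does whether the methoxy step would hold with the carbon and selenium group in place of the sulfur atom.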